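The compounds below may be only part of what the source reports. "The series", "measured", "known", "first", "only" and "open" are said of these compounds alone.

Measured so far:
- Compound 1, `CCCCNS(=O)(=O)c1ccc(Nc2ncc3c(n2)N(c2ccn(C)n2)C(CC)C(=O)N3C)cc1`: 5780 nM
- Compound 2, `CCCCNC(=O)c1ccc2c(ccn2-c2ncc3c(n2)N(C2CCCC2)[C@H](CC)C(=O)N3C)c1`: 634 nM

Both compounds were tested in a functional assay on MCF7 cells (Homo sapiens) for antiproliferative activity, read by CCK-8 assay, with a stated time of 72 h; a higher number here means a weaker inhibitor of growth, a lower number a stronger inhibitor of growth. Of the two, compound 1 gives the higher number, so it is the weaker inhibitor of growth; compound 2 gives the lower number, and the gap between them lies beyond the usual scatter of such measurements. Among the measured compounds shown here, no pair of measured compounds differs in only one place, so no single-change step has been seen yet.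

The next compound, compound 3, `CCC1C(=O)N(C)c2cnc(Nc3ccc(S(N)(=O)=O)cc3)nc2N1c1ccn(C)n1`, differs from compound 1 in one place: hydrogen in place of butyl on a sulfonamide nitrogen. Everything else in the molecule is kept. For the measured compounds named here, there is no measured step of this kind to lean on. The expectation therefore rests on the change alone: a butyl chain removed from a sulfonamide nitrogen, leaving a plain sulfamoyl group. The step from compound 1 to compound 3 is expected to be small, a 1.4-fold lower number from compound 1 to compound 3 (0.16 log units; within the scatter), with a slight lean toward a lower number. Compound 3 is therefore estimated at 4000 nM in this assay, within a range of 1000 nM to 15000 nM.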

Compound 3, concentration for 50% growth inhibition: 36600 nM
The estimate for compound 3 lay 9.2-fold (0.96 log units) below the measured number; measured number outside the range, above it.
By their numbers in this assay, from the lowest: compound 2; then compound 1; then compound 3.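

In this assay, removing the butyl group from the sulfonamide nitrogen to leave a plain sulfamoyl group gives a 6.3-fold higher number from compound 1 to compound 3 (0.80 log units; beyond the scatter), so the substituent on this nitrogen clearly affects the reading. Among the compounds shown here, this is the first single-change step seen, and with the rest of the molecule unchanged, it ties the difference to this one position: the butyl-bearing compound 1 is the stronger inhibitor of growth of this pair, and the unsubstituted compound 3 the weaker. Nothing measured here gives a reason for the size or direction of this step.

With only butyl and hydrogen shown on this nitrogen, it remains open whether the reading follows chain length, as a methyl, a propyl or a longer chain such as hexyl could reveal, or whether a chain ending in an amine or a carboxylic acid would keep the number low. On these data alone, it also remains open whether removing butyl would give a similar step on a different core, since this change has been seen only once.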